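Removing the tert-butyl group from compound 2

The compounds below may be only part of what the source reports. "The series", "measured", "known", "first", "only" and "open" are said of these compounds alone.

In an ADME assay on HEp-2 cells (Homo sapiens) for cytotoxicity (a lower number here means that less compound is tolerated, a higher number that more compound is tolerated), compound 1 `C=C(C)n1c(=O)n(Cc2nc3cc(C(=N)N)ccc3n2CCC(C)C)c2ccccc21` gives 10800 nM. For the measured compounds named here, compound 2 `CC(C)CCn1c(Cn2c(=O)n(CC(=O)OC(C)(C)C)c3ccccc32)nc2cc(C(=N)N)ccc21` gives 7900 nM, a number within the scatter of the only other measurement. Compound 3 `CC(C)CCn1c(Cn2c(=O)n(CC(=O)O)c3ccccc32)nc2cc(C(=N)N)ccc21` has not yet been measured. It differs from compound 2 by hydrogen in place of tert-butyl on an oxygen next to a carbonyl group, so that (tert-butoxycarbonyl)methyl becomes carboxymethyl. Going by the values given here, one measured step bears on this group: a 1.4-fold lower number from compound 1 to compound 2 (0.14 log units; within the scatter), with (tert-butoxycarbonyl)methyl in place of 1-methylethenyl on an aromatic nitrogen. Among the compounds with values here, no measured compound carries carboxymethyl, so the direction remains uncertain. A modest move towards a higher number is expected, and the estimated change is a 2.3-fold higher number from compound 2 to compound 3 (0.36 log units; beyond the scatter). The expected value for compound 3 is 18000 nM, within an estimated range of 7000 nM to 50000 nM.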

Compound 3, half-maximal cytotoxic concentration: 173000 nM
The estimate for compound 3 lay 9.6-fold (0.98 log units) below the measured number, and the stated range ends below it.
By their numbers in this assay, from the lowest: compounds 2 and 1 (each within the scatter of the next); then compound 3.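

In this assay, hydrogen in place of tert-butyl on an oxygen next to a carbonyl group gives a 22-fold higher number from compound 2 to compound 3 (1.34 log units; beyond the scatter), so this end of the substituent can shift the tolerated concentration by a large step. The earlier comparison of (tert-butoxycarbonyl)methyl with 1-methylethenyl on an aromatic nitrogen had stayed within the scatter, whereas carboxymethyl at that nitrogen stands clear of 1-methylethenyl too, with a 16-fold higher number from compound 1 to compound 3 (1.20 log units; beyond the scatter). Nothing available explains why this change has so large an effect.

The compounds shown leave open whether a methyl ester or a primary amide in place of the carboxylic acid would stay near compound 2 or near compound 3. They also leave open whether a longer chain between the aromatic nitrogen and the carboxy group would keep the higher number.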